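This account rests on a few compounds, and the source may have more. Where it says the series, first, only, none or still open, it means among the compounds named here.

Three compounds share one core and differ only in the group hanging from it. In a functional assay on HL-60 cells (Homo sapiens), read by calcium flux (on this read-out lower numbers stand for an effect already at smaller amounts and higher numbers for an effect only at larger amounts of compound), compound 1 `Cc1cc(Cc2cccc(Cl)c2)c(=O)n(CC(=O)Nc2ccc(Br)cc2)n1` gives only a limit of the assay, > 50000 nM. Compound 2 `Cc1cc(Cc2cccc(Br)c2)c(=O)n(CC(=O)Nc2ccc(Br)cc2)n1` likewise gives a limit, > 50000 nM. Compound 3 `Cc1cc(Cc2cccs2)c(=O)n(CC(=O)Nc2ccc(Br)cc2)n1` also stands at a limit, > 50000 nM. Because all three values sit at the limit of > 50000 nM in this assay, at which 3 of the 3 values shown sit, the steps a step that the two limits leave unreadable from compound 1 to compound 2, a step that the two limits leave unreadable from compound 1 to compound 3 and a step that the two limits leave unreadable from compound 2 to compound 3 cannot be read. Compound 4 `Cc1cc(N)c(=O)n(CC(=O)Nc2ccc(Br)cc2)n1` is not yet measured; it differs from compound 3 by amino in place of (thiophen-2-yl)methyl on an aromatic carbon. Within the data shown here, no measured step bears on this change, so nothing shows whether it moves the read-out in this assay at all. Compound 4 is therefore expected to remain at the limit, with an expected step of a number no higher from compound 3 to compound 4 (the limit leaves the size open) that is itself unreadable. The estimate for compound 4 is 50000 nM, within 10000 nM to 100000 nM.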

Compound 4, half-maximal effective concentration: > 50000 nM
Compound 4 was reported as a limit; the forecaster's own chance of this, stated with the estimate: 85%; the middle value sits exactly at the limit.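

Compound 4 also gives only a limit, so the steps to it from compound 1, compound 2 and compound 3 cannot be read: the limit of > 50000 nM in this assay, at which 4 of the 4 values shown sit. On these data alone, whether any change to the shared core gives a measurable value in this assay stays open.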